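Solubility notes: aryl swap on the fused core

This account rests on a few compounds, and the source may have more. Where it says the series, first, only, none or still open, it means among the compounds named here.

Measured compounds:
- compound 1, `Cc1cc(NCc2cccnc2)n2nc(C)c(-c3ccccc3)c2n1`: 110000 nM
- compound 2, `Cc1cc(NCc2ccccn2)n2ncc(-c3ccc(N(C)C)cc3)c2n1`: < 5000 nM

In a physicochemical assay for solubility, read by HPLC, using the shake flask method, measured as kinetic solubility, with a stated time of 2 h, at pH 7.4 (on this read-out higher numbers stand for higher solubility and lower numbers for lower solubility), compound 1 gives 110000 nM. For compound 2 this assay reports only a limit, < 5000 nM, and no number. Going by the values given here, compound 2 therefore sits at the limit of < 5000 nM in this assay, at which 1 of the 2 values shown sits, the lower end of the two values shown, while compound 1 carries the only measured number in the set.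

Compound 3 is `Cc1cc(NCc2ccccn2)n2ncc(-c3ccc(F)cc3F)c2n1`. It differs from compound 2 by 2,4-difluorophenyl in place of 4-(dimethylamino)phenyl on an aromatic carbon, with 2,4-difluorophenyl in place of 4-(dimethylamino)phenyl on an aromatic carbon. Among the compounds with values here, no step between two measured compounds covers this change, so nothing in the data fixes its size or direction. The expectation is a step of a number no lower from compound 2 to compound 3 (the limit leaves the size open), no larger than the usual scatter, with a fair chance that this assay again returns only a limit. Compound 3 is estimated at 5000 nM, expected to fall between 1000 nM and 25000 nM.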

Compound 3, solubility: < 5000 nM
Compound 3: no number, only a limit; the forecaster's own chance of this, stated with the estimate: 50%; the middle value lies on the limit itself.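

In this assay compound 3 gives only a limit, < 5000 nM, and no number. No step from compound 2 to compound 3 can be read, because both carry only a limit: the limit of < 5000 nM in this assay, at which 2 of the 3 values shown sit.

The compounds shown leave open whether 2,4-difluorophenyl in place of 4-(dimethylamino)phenyl changes the read-out at all.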